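Working notes on an isoxazole-quinoline pair

A few compounds are considered here, and "the series" means these few. Any claim that something is new, unique, unknown or untested is made for them only; others in the source may bear on it.

Measured compounds:
compound 1 `CCc1cc2ccccc2nc1-c1cc(-c2ccccc2)no1` > 100000 nM
compound 2 `CCCc1cc2ccccc2nc1-c1cc(-c2ccccc2)no1` 51300 nM

Compound 1 stands only as a limit in a functional assay on PC-3 cells (Homo sapiens) for inhibition, read by MTT assay, with a stated time of 24 h (on this read-out higher numbers stand for weaker inhibition and lower numbers for stronger inhibition), namely (the limit of > 100000 nM in this assay, at which 1 of the 2 values shown sits); no number is known for it. Compound 3 `CCc1cc2ccccc2nc1-c1cc(-c2ccc(C(F)(F)F)cc2)no1` differs from compound 1 by trifluoromethyl in place of hydrogen on an aromatic carbon. For the measured compounds named here, no measured step touches that position. Going by the values given here, the single measured step, an at least 1.9-fold lower number from compound 1 to compound 2 (0.28 log units; that floor lies within the scatter), concerns the saturated chain and starts from the same limit, so it gives no direction for compound 3. The step from compound 1 to compound 3 is therefore expected to stay within the scatter, an at least 1.4-fold lower number from compound 1 to compound 3 (0.15 log units; that floor lies within the scatter). Compound 3 is estimated at 70000 nM, with a range from 20000 nM to 200000 nM.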

Compound 3, half-maximal inhibitory concentration: > 100000 nM
Compound 3: only a limit was reported; the forecaster's own chance of this, stated with the estimate: 55%; at least 1.4-fold (0.15 log units) between middle value and limit.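

Compound 1 and compound 3 both stand only as limits, so no step can be read between them: the limit of > 100000 nM in this assay, at which 2 of the 3 values shown sit.

The compounds shown leave open what trifluoromethyl in place of hydrogen on an aromatic carbon does in this assay.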